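Trimming a methyl from the butyl on the amide nitrogen

The source may hold more compounds than are shown below. What is called first, only, known or untested is meant among the compounds shown, and "the series" means these compounds.

Three compounds share one core and differ only in the group attached to the carbonyl carbon. Compound 1 `CCCOC(=O)/C=C/c1ccccc1` carries a propoxy group, and in a functional assay on the whole organism for inhibition, with Brassica rapa subsp. chinensis as the target, with a stated time of 3 days, tested at 100 ppm (on this read-out higher numbers stand for more inhibition of growth at the one concentration tested and lower numbers for less inhibition of growth), compound 1 gives 7%. Compound 2 `CC(C)(C)NC(=O)/C=C/c1ccccc1` carries a (tert-butyl)amino group and gives 73%, while compound 3 `CCC(C)NC(=O)/C=C/c1ccccc1` carries a (sec-butyl)amino group and gives 77%, the highest of the three numbers shown, though the gap to compound 2 is within the scatter. The two exchanges of propoxy for an amino group, a number 66 percentage points higher from compound 1 to compound 2 (beyond the scatter) and a number 70 percentage points higher from compound 1 to compound 3 (beyond the scatter), are large; the exchange of one butyl for the other on the amide-type nitrogen, a number 4 percentage points higher from compound 2 to compound 3 (within the scatter), is not.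

Compound 4 `CCCNC(=O)/C=C/c1ccccc1` is reached from compound 3 by hydrogen in place of methyl on a saturated chain carbon bound to an amide-type nitrogen and a saturated chain carbon. Of the measured steps, a number 4 percentage points higher from compound 2 to compound 3 (within the scatter) bears most directly on it: that step also altered only the butyl group on the amide-type nitrogen and left the amino link in place. A step of little or no size beyond the scatter is therefore expected, a number 5 percentage points lower from compound 3 to compound 4 (within the scatter). Compound 4 is estimated to give 72%, within 55% to 88%.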

Compound 4, percent growth inhibition at one concentration: 63%
Estimate against measurement, compound 4: 9 percentage points above, and the stated range covers the measured number.
By their numbers in this assay, from the lowest: compound 1; then compounds 4, 2 and 3 (each within the scatter of the next, the first and the last beyond it).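

In this assay, among the compounds shown here, hydrogen in place of methyl is the first change to the group on the amide-type nitrogen that moves the number beyond the scatter (a number 14 percentage points lower from compound 3 to compound 4 (beyond the scatter)), so this position does respond to the exact chain it carries. The picture is not a simple one, though: the exchange of tert-butyl for propyl stays within the scatter (a number 10 percentage points lower from compound 2 to compound 4 (within the scatter)), while propylamino in place of propoxy still gives a large step (a number 56 percentage points higher from compound 1 to compound 4 (beyond the scatter)), so the amino link keeps most of the number even with the propyl chain. Nothing available explains why the sec-butyl and propyl compounds part.

The compounds shown leave open what a longer chain such as pentyl, or a cyclohexyl ring, would give on the amide-type nitrogen. They also leave open what a second methyl on that nitrogen, in place of the amide hydrogen, would do.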